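Trimethoxyphenyl amides: saturated versus unsaturated acyl chain

The source may hold more compounds than are shown below. What is called first, only, known or untested is meant among the compounds shown, and "the series" means these compounds.

Measured so far in a functional assay on KYSE-450 cells (Homo sapiens) for inhibition, read by MTT assay, with a stated time of 48 h; a higher number here means a weaker inhibitor, a lower number a stronger inhibitor:
- compound 1, `COc1cc(NCc2ccccc2)cc(OC)c1OC`; compound 1 gives > 80000 nM, which is a limit of this assay and not a number
- compound 2, `CCCCC(=O)N(Cc1ccc(OC)c(O)c1)c1cc(OC)c(OC)c(OC)c1`; compound 2 gives 300 nM
- compound 3, `COc1ccc(CNc2cc(OC)c(OC)c(OC)c2)cc1Cl`; compound 3 gives 47800 nM

Of the two numbers in this assay, compound 2 stands lowest; the nearest number, that of compound 3, lies far higher and beyond the usual scatter. Compound 1 sits at the limit of this assay (the limit of > 80000 nM in this assay, at which 1 of the 3 values shown sits), so it is not ranked against the other two.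

Compound 4, `CC/C=C/C(=O)N(Cc1ccc(OC)c(O)c1)c1cc(OC)c(OC)c(OC)c1`, is not yet measured. It differs from compound 2 in one place: but-1-en-1-yl in place of butyl on a carbonyl carbon. Going by the values given here, neither measured step involves the acyl chain, so no measured step informs this change. The double bond enters without any change in heavy-atom count, ring count, donors or acceptors, and the step from compound 2 to compound 4 is expected to be small, a 1.2-fold lower number from compound 2 to compound 4 (0.08 log units; within the scatter), not beyond the scatter. Compound 4 is therefore estimated at 250 nM, with a range of 90 nM to 800 nM.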

Compound 4, half-maximal inhibitory concentration: 72 nM
Compound 4: the middle estimate sits 3.5-fold (0.54 log units) above what was measured; the whole stated range lies above it.
By their numbers in this assay, from the lowest: compound 4; then compound 2; then compound 3. At a limit, above all of these: compound 1.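

In this assay, the acyl chain proves to be a position where a small edit registers: a 4.2-fold lower number from compound 2 to compound 4 (0.62 log units; beyond the scatter). Going by these compounds alone, compound 1 and compound 3 carry no acyl group on the nitrogen, so they said nothing about this place; this is the first reading of a change on the carbonyl carbon. The swap of butyl for but-1-en-1-yl adds one double bond outside aromatic rings while heavy atoms, donors and acceptors stay the same in count, and nothing measured here bears on why the number moves.

Going by these compounds, the trend rests on a single pair on one core, so it remains open whether the double bond itself or its trans geometry carries the step. Also open, on these data alone, is how a but-1-yn-1-yl group, a longer chain or a terminal carboxylic acid would read at this place.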